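The source may hold more compounds than are shown below. What is called first, only, known or untested is meant among the compounds shown, and "the series" means these compounds.

Of the compounds shown here, three share one core and have been tested in an ADME assay on Vero cells (Chlorocebus sabaeus) for cytotoxicity, read by MTT assay, tested at 100 uM; on this read-out higher numbers stand for a weaker effect at the one concentration tested and lower numbers for a stronger effect. Compound 1 `CCOC(=O)C(C(=O)c1ccc(OC)cc1)C(NC(C)=O)c1ccc(C(C)C)cc1` gives 90.4% in this assay, and compound 2 `CCOC(=O)C(C(=O)c1ccc(OC)cc1)C(NC(C)=O)c1ccc(C(C)(C)C)cc1` gives 89.5%. Among the measured compounds shown here, the only step between two compounds that differ in one place is a number 0.9 percentage points lower from compound 1 to compound 2 (within the scatter), so adding a methyl at that position made no difference that can be told from noise. Compound 3 `CCOC(=O)C(C(=O)c1ccc(OC)cc1)C(NC(C)=O)c1cc(OC)c(OC)c(OC)c1`, which carries three methoxy groups on one of its rings, gives 88.9% in this assay. Its number sits within the usual scatter of both compound 1 and compound 2, so all three compounds look alike here: each leaves most of the cells alive at the single concentration tested.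

Compound 4 `CCOC(=O)C(C(=O)c1ccc(OC)cc1)C(NC(C)=O)c1ccc(OC)c(OC)c1` has not yet been measured. It differs from compound 3 by hydrogen in place of methoxy on an aromatic carbon. For the measured compounds named here, no measured step removes or adds a methoxy, so nothing already seen speaks directly to this change; the one step that exists, from compound 1 to compound 2, was within the scatter. With all three measured numbers close together, compound 4 is expected to stay in the same region, with a step of a number 0.1 percentage points higher from compound 3 to compound 4 (within the scatter) that is not expected to exceed the scatter. The estimate for compound 4 in this assay is therefore 89%, with a likely range from 80% to 96%.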

Compound 4, a percentage reported as activity, at one concentration (the size of the read-out at that concentration, not a potency): 88.5%
For compound 4 the middle estimate is 0.5 percentage points above the measured one; low and high end bracket the measured number.
By their numbers in this assay, from the lowest: compounds 4, 3, 2 and 1 (each within the scatter of the next).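

Among the compounds shown here, compound 4 gives the first direct look at a methoxy group on this aromatic ring, at the place ortho to a methoxy group and meta to a large group, and hydrogen there cannot be told apart from methoxy in this assay: the step is a number 0.4 percentage points lower from compound 3 to compound 4 (within the scatter). The 3,4-dimethoxyphenyl group of compound 4 also cannot be told apart from the two alkyl-bearing rings, with a number 1 percentage points lower from compound 2 to compound 4 (within the scatter) and a number 1.9 percentage points lower from compound 1 to compound 4 (within the scatter), so among these four compounds neither the number of methoxy groups nor the swap from 4-(tert-butyl)phenyl or 4-isopropylphenyl to 3,4-dimethoxyphenyl shows a step beyond the scatter. No measurement at hand offers an explanation for how alike these numbers are.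

Every ring substituent shown here is a methoxy, isopropyl or tert-butyl group, so it remains open whether an amine or a carboxylic acid on this ring would give a number outside the scatter. Going by these compounds, with a single concentration behind each number, it also remains open whether these compounds would separate at any other concentration.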